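The source may report more compounds than this note shows. Statements on the series, on what has been measured and on what is new or still open speak of the compounds shown alone.

Compound 1 `COc1ccc(-c2nnc(CCC(=O)c3ccc(C)cc3)o2)cc1` gives 69.3% in a functional assay on the whole organism (strain Wistar) for inhibition, with Rattus norvegicus as the target, with stated times of 30 min and 2 h, at a dose of 20 mg/kg by the oral route; on this read-out higher numbers stand for more inhibition at the one dose given (going by the name of the read-out) and lower numbers for less inhibition.
Compound 2 `Cc1ccc(C(=O)CCc2nnc(Cc3ccccc3)o2)cc1` gives 24.7% in this assay.

For the measured compounds named here, compound 2 stands lowest of the two numbers in this assay; the only measured step is a number 44.6 percentage points lower from compound 1 to compound 2 (beyond the scatter), a large drop. Compound 3 `Cc1ccc(C(=O)CCc2nnc(COc3ccccc3)o2)cc1` differs from compound 2 by phenoxy in place of phenyl on a saturated chain carbon bound to an aromatic carbon. Going by the values given here, no measured step bears directly on this change, since the one known step concerns a different group. A small rise is therefore expected, within or near the scatter, as a number 10.3 percentage points higher from compound 2 to compound 3 (beyond the scatter). Compound 3 is estimated to give 35% in this assay, with a range from 15% to 60%.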

Compound 3, a percentage reported as inhibition, in the whole organism at one dose (the size of the read-out at that dose, not a potency): 25.3%
Compound 3: middle estimate off by 9.7 percentage points, on the high side; the measured number falls inside the stated range.
By their numbers in this assay, from the lowest: compounds 2 and 3 (each within the scatter of the next); then compound 1.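

Phenoxy in place of phenyl on this saturated chain carbon gives a number 0.6 percentage points higher from compound 2 to compound 3 (within the scatter) in this assay, so the two groups cannot be told apart on this read-out. Phenoxymethyl also lies well under 4-methoxyphenyl, with a number 44 percentage points lower from compound 1 to compound 3 (beyond the scatter), which shows that the earlier drop is not confined to benzyl. Nothing available explains these results.

As far as these compounds go, it remains open whether plain phenyl on the aromatic carbon would keep the number of compound 1. From the compounds shown here alone, what an amine or a carboxylic acid in place of phenoxy would give is also open.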